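Adding One Methyl to Compound 2

A few compounds are considered here, and "the series" means these few. Any claim that something is new, unique, unknown or untested is made for them only; others in the source may bear on it.

Of the compounds shown here, two with a shared core have been tested so far in a functional assay on A549 cells (Homo sapiens) for antiproliferative activity, read by MTT assay, with a stated time of 72 h; a lower number here means a stronger inhibitor, a higher number a weaker inhibitor. Compound 1 `COc1ccc(SC(=S)N2CCN(C(=O)OC(C)(C)C)CC2)cc1`, with a 4-methoxyphenyl on a sulfur, gives 712 nM. Compound 2 `Cc1ccccc1SC(=S)N1CCN(C(=O)OC(C)(C)C)CC1`, with a 2-methylphenyl there, gives 2270 nM, the higher and therefore weaker of the two numbers. Compound 3 `Cc1ccc(C)c(SC(=S)N2CCN(C(=O)OC(C)(C)C)CC2)c1` is still unmeasured. It is compound 2 with methyl in place of hydrogen on an aromatic carbon, meta to a large group and para to a methyl group: methyl in place of hydrogen on an aromatic carbon. This turns 2-methylphenyl into 2,5-dimethylphenyl. Among the measured compounds shown here, the only measured step, a 3.2-fold higher number from compound 1 to compound 2 (0.50 log units; beyond the scatter), swapped the whole group, so it is a loose guide, and no measured step adds a single methyl. No step beyond the usual scatter is expected, and the data favour no direction. The estimated step is a 1.1-fold lower number from compound 2 to compound 3 (0.05 log units; within the scatter). Compound 3 is expected at 2000 nM, within a range of 700 nM to 5500 nM.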

Compound 3, half-maximal inhibitory concentration: 539 nM
Estimate against measurement, compound 3: 3.7-fold (0.57 log units) above, and the stated range ends above it.
By their numbers in this assay, from the lowest: compounds 3 and 1 (each within the scatter of the next); then compound 2.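

In this assay, one added methyl on an aromatic carbon, meta to a large group and para to a methyl group, is enough to shift the result beyond the usual scatter (a 4.2-fold lower number from compound 2 to compound 3 (0.62 log units; beyond the scatter)). The earlier step exchanged a whole group, whereas this one shows that a single carbon at this position matters on its own. The 2,5-dimethylphenyl and 4-methoxyphenyl groups on the sulfur cannot be told apart here (a 1.3-fold lower number from compound 1 to compound 3 (0.12 log units; within the scatter)), and nothing measured explains the effect of the methyl.

From the compounds shown here alone, whether an ethyl chain, a chlorine atom or an amine on this same carbon would act like the methyl remains open. It is also unknown whether this methyl would have the same effect without the other methyl on the ring.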